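Swapping a pyridine substituent for cyclohexenyl

This account rests on a few compounds, and the source may have more. Where it says the series, first, only, none or still open, it means among the compounds named here.

In a functional assay on MDA-MB-436 cells (Homo sapiens) for antiproliferative activity, read by MTT assay, with a stated time of 48 h (a lower number here means a stronger inhibitor, a higher number a weaker inhibitor), compound 1 `C=CS(=O)(=O)N1CCN(c2ncnc3sc(-c4ccc(C(F)(F)F)cc4)cc23)CC1` gives 7080 nM, compound 2 `C=CS(=O)(=O)N1CCN(c2ncnc3sc(-c4ccnc(Cl)c4)cc23)CC1` gives 30100 nM and compound 3 `C=CS(=O)(=O)N1CCN(c2ncnc3sc(-c4cc(Br)cnc4F)cc23)CC1` gives 28400 nM. The two pyridine compounds are not separated, a 1.1-fold lower number from compound 2 to compound 3 (0.03 log units; within the scatter), and both read higher than the phenyl compound: a 4.3-fold higher number from compound 1 to compound 2 (0.63 log units; beyond the scatter) and a 4.0-fold higher number from compound 1 to compound 3 (0.60 log units; beyond the scatter).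

Compound 4 `C=CS(=O)(=O)N1CCN(c2ncnc3sc(C4=CCCCC4)cc23)CC1` has cyclohex-1-en-1-yl in place of 5-bromo-2-fluoropyridin-3-yl on an aromatic carbon next to the ring sulfur: cyclohex-1-en-1-yl in place of 5-bromo-2-fluoropyridin-3-yl on an aromatic carbon. Within the data shown here, no measured step tests a non-aromatic ring. The new ring is carbon-only, as is the ring of compound 1, so part of the reverse of a 4.0-fold higher number from compound 1 to compound 3 (0.60 log units; beyond the scatter) is expected in this assay. The expected change is a 2.2-fold lower number from compound 3 to compound 4 (0.34 log units; beyond the scatter). The estimate for compound 4 is 13000 nM, with an expected range of 5000 nM to 35000 nM.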

Compound 4, half-maximal inhibitory concentration: > 50000 nM
Compound 4: no number, only a limit; the forecaster's own chance of this, stated with the estimate: 10%; at least 3.8-fold (0.58 log units) between middle value and limit.
By their numbers in this assay, from the lowest: compound 1; then compounds 3 and 2 (each within the scatter of the next). At a limit, above all of these: compound 4.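

In this assay compound 4 stands only at a limit of the assay: the limit of > 50000 nM in this assay, at which 1 of the 4 values shown sits. A carbon-only ring at this position is therefore not enough to keep the lower number of compound 1, with an at least 7.0-fold higher number from compound 1 to compound 4 (0.84 log units; beyond the scatter). Against the pyridines the floors are an at least 1.7-fold higher number from compound 3 to compound 4 (0.24 log units; that floor lies within the scatter) and an at least 1.6-fold higher number from compound 2 to compound 4 (0.22 log units; that floor lies within the scatter), so compound 4 is not shown to differ from either.

Going by these compounds, how far compound 4 lies past its limit stays unknown. Also open, on these data alone, is whether a saturated cyclohexyl ring, or an amine or carboxylic acid on the phenyl ring of compound 1, would change the number.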